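Thienyl-free notes: a limit-bound series and one new amine

This account rests on a few compounds, and the source may have more. Where it says the series, first, only, none or still open, it means among the compounds named here.

Measured in a functional assay on L02 cells (Homo sapiens) for inhibition, read by Griess assay, with stated times of 1 h and 24 h; a higher number here means a weaker inhibitor, a lower number a stronger inhibitor:
- compound 1 `CN(C)c1nc(/C=C/c2ccccc2)nc2ccsc12`: > 1000000 nM, a limit
- compound 2 `Brc1ccc(Nc2nc(/C=C/c3ccccc3)nc3ccsc23)cc1`: > 1000000 nM, a limit

Compound 2 has no numerical reading, only its limit of > 1000000 nM. Going by the values given here, both compounds measured so far stand at the same limit: the limit of > 1000000 nM in this assay, at which 2 of the 2 values shown sit. Among the compounds with values here, the only measured step is a step that the two limits leave unreadable from compound 1 to compound 2, so it supplies no size and no direction to carry forward.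

Compound 3 `COc1cccc(CNc2nc(/C=C/c3ccccc3)nc3ccsc23)c1` is the next to be read, and the change is 3-methoxybenzyl in place of 4-bromophenyl on a nitrogen on an aromatic ring. It places 3-methoxybenzyl in place of 4-bromophenyl on a nitrogen on an aromatic ring. With so little to go on, a weak reading in this assay is the expectation, resting on the two readings so far, (the limit of > 1000000 nM in this assay, at which 2 of the 2 values shown sit). A result at the same limit is the most likely outcome, although a readable number on the stronger side cannot be excluded.

For compound 3 the expected value is 600000 nM, with an estimated range of 50000 nM to 2000000 nM. The estimate means an expected at least 1.6-fold lower number from compound 2 to compound 3 (0.22 log units; that floor lies within the scatter).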

Compound 3, half-maximal inhibitory concentration: > 1000000 nM
Compound 3: no number, only a limit; the forecaster's own chance of this, stated with the estimate: 65%; at least 1.6-fold (0.22 log units) between middle value and limit.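

In this assay compound 3 gives > 1000000 nM, a limit and not a number, so no step can be read between compound 2 and compound 3, and the series stays at one value: the limit of > 1000000 nM in this assay, at which 3 of the 3 values shown sit.

The compounds shown leave open whether any substituent on the shared core gives a readable number in this assay.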